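Swapping the ketal ring on the pyrazole nitrogen

The compounds below may be only part of what the source reports. "The series", "measured", "known", "first", "only" and "open" are said of these compounds alone.

Measured compounds:
compound 1, `CNC(=O)Nc1ccc(-c2nc(N3CC4CCC(C3)O4)c3cnn(C4CCC5(CC4)OCCCO5)c3n2)cc1` — > 0.5 h
compound 2, `O=C(Nc1ccc(-c2nc(N3CC4CCC(C3)O4)c3cnn(C4CCC5(CC4)OCCO5)c3n2)cc1)NC1CC1` — 0.417 h

Compound 1 was tested in an in vitro ADME assay on microsomes (Mus musculus) for metabolic stability; a lower number here means that the compound disappears faster, a higher number that the compound lasts longer. For compound 1 this assay reports only a limit, > 0.5 h — a boundary of what the assay can read, not a number. Compound 2, `O=C(Nc1ccc(-c2nc(N3CC4CCC(C3)O4)c3cnn(C4CCC5(CC4)OCCO5)c3n2)cc1)NC1CC1`, gives 0.417 h in this assay. Compound 1 thus sits at the limit of > 0.5 h in this assay, at which 1 of the 2 values shown sits, and where it truly lies beyond that is not known.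

Compound 3, `CNC(=O)Nc1ccc(-c2nc(N3CC4CCC(C3)O4)c3cnn(C4CCC(OC)(OC)CC4)c3n2)cc1`, has not yet been measured. It differs from compound 1 in one place: a group of 10 heavy atoms (8 carbon, 2 oxygen; one six-membered non-aromatic ring of carbon only) in place of a group of 11 heavy atoms (9 carbon, 2 oxygen; one six-membered non-aromatic ring of carbon only, one six-membered non-aromatic ring with 2 hetero atoms), on an aromatic nitrogen. No measured pair of compounds isolates a change of this kind, so the size of the step cannot be read from the data shown.

Since compound 1 gives only a limit, the expectation for compound 3 rests on little. The step of a number no higher from compound 1 to compound 3 (the limit leaves the size open) is expected to stay within the usual scatter, in either direction. Compound 3 is therefore estimated at 0.5 h in this assay, with a plausible range from 0.25 h to 1 h.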

Compound 3, half-life: 0.25 h
For compound 3 the middle estimate is 2.0-fold (0.30 log units) above the measured one; the measured number falls inside the stated range.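

Going by these compounds alone, this pair is the first in which only the group on the aromatic nitrogen changes, so the effect of that group can be looked at on its own. Compound 1 has a six-membered ring with 2 hetero atoms built onto the carbon ring, while compound 3 keeps only the carbon ring and its 2 oxygen atoms, and in this assay this change gives an at least 2.0-fold lower number from compound 1 to compound 3 (0.30 log units; that floor lies within the scatter). The direction is therefore known, but the smallest step the numbers allow does not go beyond the usual scatter, and the true size remains unknown because compound 1 carries only a limit of the assay, not a number: the limit of > 0.5 h in this assay, at which 1 of the 3 values shown sits.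

On these data alone, whether the same change would give a similar step on the cyclopropyl urea of compound 2 remains open, since one pair cannot show whether the step depends on the rest of the molecule. As far as these compounds go, it is also open how a plain cyclohexyl ring with no oxygen, a ketone or a hydroxyl group would behave on this nitrogen, and so whether the oxygen atoms matter at all.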